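A Methyl Added to a Weakly Active Compound

This account rests on a few compounds, and the source may have more. Where it says the series, first, only, none or still open, it means among the compounds named here.

In a functional assay on A549 cells (Homo sapiens) for antiproliferative activity, read by sulforhodamine B assay, with a stated time of 48 h (on this read-out higher numbers stand for weaker inhibition and lower numbers for stronger inhibition), compound 1 (`COc1ccc2nc(-c3ccc(N/C=C\C(=O)c4ccc(OC)c(F)c4)c(C)c3)sc2c1`) gives 1400 nM, and compound 2 (`COc1ccc2nc(-c3ccc(N/C=C\C(=O)c4ccc(OC)c([N+](=O)[O-])c4)cc3)sc2c1`) gives 13600 nM. Compound 2 therefore has the higher of the two numbers, which means the weaker inhibition, and the gap lies beyond the usual scatter. Compound 3 (`COc1ccc2nc(-c3ccc(N/C=C\C(=O)c4ccc(OC)c([N+](=O)[O-])c4)c(C)c3)sc2c1`) is compound 2 with one change: methyl in place of hydrogen on an aromatic carbon, a methyl in place of hydrogen on an aromatic carbon. Among the measured compounds shown here, no measured pair shows this change alone. Compound 1 also bears that methyl and gives 1400 nM, but it differs from compound 2 in more than one place, so it offers only a loose hint. A moderate move towards stronger inhibition is expected, although a result within the scatter remains possible. The expected step is a 2.7-fold lower number from compound 2 to compound 3 (0.43 log units; beyond the scatter). For compound 3, the estimated value is 5000 nM, with an expected range from 1500 nM to 15000 nM.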

Compound 3, half-maximal inhibitory concentration: 13600 nM
Compound 3: the middle estimate sits 2.7-fold (0.43 log units) below what was measured; measured number inside the range.
By their numbers in this assay, from the lowest: compound 1; then compounds 2 and 3 (each within the scatter of the next).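

In this assay, methyl in place of hydrogen on this aromatic carbon, ortho to a large group, now has a pair of its own, and with the nitro group present it gives no change at the digits printed from compound 2 to compound 3 (within the scatter). With that methyl held constant, nitro in place of fluoro on an aromatic carbon gives a 9.7-fold higher number from compound 1 to compound 3 (0.99 log units; beyond the scatter), so in this set the clear difference follows the nitro and fluoro groups, not the methyl. Nothing measured here explains either result.

The compounds shown leave open whether the methyl also makes no readable difference when fluoro stands in place of nitro. They also leave open whether an ethyl group or an amine on the same aromatic carbon would give a different number from hydrogen or methyl.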